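The compounds below may be only part of what the source reports. "The series", "measured", "known", "first", "only" and "open" are said of these compounds alone.

Measured in a functional assay on NPC-TW01 cells (Homo sapiens) for inhibition, read by MTT assay, with a stated time of 72 h; a higher number here means a weaker inhibitor of growth, a lower number a stronger inhibitor of growth:
compound 1 `CN(C)/C=N/c1c(C=O)c(-c2ccccc2)nn1-c1ccccc1` gives 9300 nM
compound 2 `CN(C)/C=N/c1c(C=O)c(-c2ccccc2)nn1-c1ccc(Br)cc1` gives 7400 nM
compound 3 `Cc1ccc(-c2nn(-c3ccccc3)c(/N=C/N(C)C)c2C=O)cc1` gives 9700 nM

Compound 1 stands second highest of the three numbers in this assay. The two steps away from it are small: a 1.0-fold higher number from compound 1 to compound 3 (0.02 log units; within the scatter) and a 1.3-fold lower number from compound 1 to compound 2 (0.10 log units; within the scatter), both within the scatter, so the three compounds cannot be ordered against one another.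

Compound 4 `O=Cc1c(-c2ccccc2)nn(-c2ccccc2)c1/N=C/N1CCCCC1` differs from compound 1 by piperidin-1-yl in place of dimethylamino on a carbon with a double bond to nitrogen. Neither measured step touches this position; both concern a hydrogen on an aromatic carbon and both stayed within the scatter. Within the data shown here, no measured step therefore bears directly on the change, and no step beyond the scatter is expected in this assay.

Compound 4 is accordingly estimated at 9000 nM, with a range of 4000 nM to 20000 nM, which means an expected step of a 1.0-fold lower number from compound 1 to compound 4 (0.01 log units; within the scatter).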

Compound 4, concentration for 50% growth inhibition: 24400 nM
Compound 4: the middle estimate sits 2.7-fold (0.43 log units) below what was measured, and the stated range ends below it.
By their numbers in this assay, from the lowest: compounds 2, 1 and 3 (each within the scatter of the next); then compound 4.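

Among these compounds, a step of a 2.6-fold higher number from compound 1 to compound 4 (0.42 log units; beyond the scatter) makes the carbon with a double bond to nitrogen the only place so far where one change moves the number in this assay beyond the scatter. Piperidin-1-yl in place of dimethylamino gives a modestly weaker inhibitor of growth, whereas the replacements of hydrogen on an aromatic carbon stayed within the scatter. No measurement on hand accounts for this step.

Still open, going by these compounds, is whether the ring itself or the higher heavy-atom count goes with the step. Pyrrolidin-1-yl, morpholin-4-yl or diethylamino at this place would help separate the two.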